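Sulfanyl side-chain exchange on the shared core

The source may report more compounds than this note shows. Statements on the series, on what has been measured and on what is new or still open speak of the compounds shown alone.

Compound 3 `CC(C(=O)NCc1ccc(C(C)(C)C)nc1SCCCN1CCCC1)c1ccc(NS(C)(=O)=O)c(F)c1` carries the (3-(pyrrolidin-1-yl)propyl)sulfanyl group on the shared core. In an assay on cells for antagonist activity at transient receptor potential cation channel subfamily V member 1 (Homo sapiens), read by FLIPR and calcium flux, with a stated time of 6 min (a higher number here means a weaker inhibitor, a lower number a stronger inhibitor), compound 3 gives 17.1 nM, the second highest of the three numbers. Compound 1 `CCOc1nc(C(C)(C)C)ccc1CNC(=O)C(C)c1ccc(NS(C)(=O)=O)c(F)c1` gives 14.8 nM, and compound 2 `CC(C(=O)NCc1ccc(C(C)(C)C)nc1SCCCN(C)C)c1ccc(NS(C)(=O)=O)c(F)c1` gives 51.8 nM. The two steps that lead to compound 3 are a 1.2-fold higher number from compound 1 to compound 3 (0.06 log units; within the scatter) and a 3.0-fold lower number from compound 2 to compound 3 (0.48 log units; beyond the scatter); the remaining step is a 3.5-fold higher number from compound 1 to compound 2 (0.54 log units; beyond the scatter).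

Compound 4 `CC(C(=O)NCc1ccc(C(C)(C)C)nc1SCc1ccccc1Cl)c1ccc(NS(C)(=O)=O)c(F)c1` differs from compound 3 by one change: 2-chlorophenyl in place of 2-(pyrrolidin-1-yl)ethyl on a saturated chain carbon bound to a sulfur. Among the measured compounds shown here, no measured step exchanges the pyrrolidin-1-yl end for a group without a hydrogen-bond acceptor, so the direction is not fixed by the data. The two steps that bear on this position, a 1.2-fold higher number from compound 1 to compound 3 (0.06 log units; within the scatter) and a 3.0-fold lower number from compound 2 to compound 3 (0.48 log units; beyond the scatter), show that changes at the sulfanyl chain move the number modestly at most. A step within or just beyond the scatter is therefore expected, with the direction uncertain.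

For compound 4 the expected value is 22 nM, with a range from 6 nM to 80 nM. The expected step is a 1.3-fold higher number from compound 3 to compound 4 (0.11 log units; within the scatter).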

Compound 4, inhibition constant: 3.8 nM
Compound 4: the middle estimate sits 5.8-fold (0.76 log units) above what was measured; measured number below the stated range.
By their numbers in this assay, from the lowest: compound 4; then compounds 1 and 3 (each within the scatter of the next); then compound 2.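

In this assay, the sulfanyl chain need not end in an amine: 2-chlorophenyl in place of 2-(pyrrolidin-1-yl)ethyl gives a 4.5-fold lower number from compound 3 to compound 4 (0.65 log units; beyond the scatter), and in place of 2-(dimethylamino)ethyl it gives a 14-fold lower number from compound 2 to compound 4 (1.13 log units; beyond the scatter), the only large step among these compounds. The (2-chlorobenzyl)sulfanyl group also separates from ethoxy, with a 3.9-fold lower number from compound 1 to compound 4 (0.59 log units; beyond the scatter), whereas the (3-(pyrrolidin-1-yl)propyl)sulfanyl group does not, with a 1.2-fold higher number from compound 1 to compound 3 (0.06 log units; within the scatter), so compound 4 is the strongest inhibitor of the four. No supporting data bear on why these steps occur.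

The exchange removes the amine and brings in both the aromatic ring and the chlorine, so the compounds shown do not separate these contributions. A plain benzyl group on the sulfur would separate the ring from the chlorine, and a 2-chlorobenzyloxy group in place of the (2-chlorobenzyl)sulfanyl group would test the sulfur link itself.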